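Linker hydroxy removal in the cathepsin S series

This account rests on a few compounds, and the source may have more. Where it says the series, first, only, none or still open, it means among the compounds named here.

Measured compounds:
- compound 1 `CS(=O)(=O)N1CCc2c(c(-c3ccc(C(F)(F)F)cc3)nn2CC(O)CN2CCC(n3c(O)nc4ccc(Cl)cc43)CC2)C1`: 60 nM
- compound 2 `Cc1ccc2c(c1)n(C1CCN(CC(O)Cn3nc(-c4ccc(C(F)(F)F)cc4)c4c3CCN(S(C)(=O)=O)C4)CC1)c(=O)n2C`: 30 nM
- compound 3 `Cn1c(=O)n(C2CCN(CC(O)Cn3nc(-c4ccc(C(F)(F)F)cc4)c4c3CCN(S(C)(=O)=O)C4)CC2)c2cc(Cl)ccc21`: 80 nM

Three compounds share the same core and differ only in the group carried on the saturated ring carbon. In an assay on isolated protein for inhibition of cathepsin S (Homo sapiens) (on this read-out lower numbers stand for stronger inhibition and higher numbers for weaker inhibition), compound 1 gives 60 nM, the second highest of the three numbers; its nearest neighbour is compound 3, the step being a 1.3-fold higher number from compound 1 to compound 3 (0.12 log units; within the scatter), and the step of a 2.0-fold lower number from compound 1 to compound 2 (0.30 log units; within the scatter) is also within the scatter. Within the data shown here, the only step beyond the scatter is a 2.7-fold higher number from compound 2 to compound 3 (0.43 log units; beyond the scatter).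

Compound 4 `CS(=O)(=O)N1CCc2c(c(-c3ccc(C(F)(F)F)cc3)nn2CCCN2CCC(n3c(O)nc4ccc(Cl)cc43)CC2)C1` has not been measured. Against compound 1 the change is hydrogen in place of hydroxy on a saturated chain carbon bound to two saturated chain carbons. Among the measured compounds shown here, all three measured steps concern the group on the saturated ring carbon, so none of them bears on a change in the linker chain; the set gives no measured step for removing this hydroxy. With nothing to go on, the expectation rests on compound 1 alone, and a step no larger than the scatter is assumed as the working case, with a wide range to cover a loss.

Compound 4 is therefore expected to give about 100 nM in this assay, in the range 30 nM to 350 nM, which would mean an estimated step of a 1.7-fold higher number from compound 1 to compound 4 (0.22 log units; within the scatter) from compound 1.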

Compound 4, half-maximal inhibitory concentration: 30 nM
Estimate against measurement, compound 4: 3.3-fold (0.52 log units) above; the measured number falls inside the stated range.
By their numbers in this assay, from the lowest: compounds 2, 4, 1 and 3 (each within the scatter of the next, the first and the last beyond it).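

In this assay, hydrogen in place of hydroxy on a saturated chain carbon bound to two saturated chain carbons gives a 2.0-fold lower number from compound 1 to compound 4 (0.30 log units; within the scatter), so with the group on the saturated ring carbon held as in compound 1, the hydroxy, with its 1 hydrogen-bond donor and 1 hydrogen-bond acceptor, is not required for inhibition in this range. Among these compounds, this is the only step in the set that reads on the linker chain, as all earlier steps concern the group on the saturated ring carbon, and it shows that this chain carbon accepts the loss of the hydroxy without a difference beyond the scatter. No supporting measurement bears on why the two compounds read alike, so the result stands as an observation only.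

On these data alone, it remains open whether the same holds when hydrogen replaces hydroxy in compound 2 or compound 3, whose groups on the saturated ring carbon differ from that of compound 1. Also open, as far as these compounds go, is how this assay responds at this chain carbon to an amine, a fluoro or a methoxy group, or to a longer chain between the shared core and the saturated ring.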